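Replacing the Methoxyphenyl Thioether Substituent of Compound 1

The source may hold more compounds than are shown below. What is called first, only, known or untested is meant among the compounds shown, and "the series" means these compounds.

Compound 1 `CCOC(=O)c1c(CSc2ccccc2OC)n(C)c2ccc(O)cc12` has the higher of the two numbers recorded in an assay on cells for inhibition of Polyunsaturated fatty acid 5-lipoxygenase (Homo sapiens), read by HPLC, with a stated time of 15 min; a lower number here means a stronger inhibitor, a higher number a weaker inhibitor: compound 1 gives 5100 nM, whereas compound 2 `CCOC(=O)c1c(CSc2ccccc2C(F)(F)F)n(C)c2ccc(O)cc12` gives 1200 nM. Among the compounds with values here, the single step connecting them, a 4.3-fold lower number from compound 1 to compound 2 (0.63 log units; beyond the scatter), comes from trifluoromethyl in place of methoxy on an aromatic carbon. Compound 3 `CCOC(=O)c1c(CSc2cccc(Cl)c2)n(C)c2ccc(O)cc12` differs from compound 1 by 3-chlorophenyl in place of 2-methoxyphenyl on a sulfur. Within the data shown here, the step from compound 1 to compound 2 is the only one that bears on this change, since it also removes the methoxy group, and it was modest; no measured compound carries chlorine, so the new group has no direct precedent. A lowering beyond the scatter, somewhat smaller than the measured step, is therefore expected. Compound 3 is estimated to give 2000 nM in this assay, in the range 700 nM to 6000 nM. That estimate corresponds to an expected 2.6-fold lower number from compound 1 to compound 3 (0.41 log units; beyond the scatter).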

Compound 3, half-maximal inhibitory concentration: > 10000 nM
Compound 3 gave a limit, no number (the forecaster's own chance of this, stated with the estimate: 5%); middle value at least 5.0-fold (0.69 log units) away from the limit.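

Compound 3 stands at a limit and not at a number: the limit of > 10000 nM in this assay, at which 1 of the 3 values shown sits. The change to 3-chlorophenyl gives an at least 1.9-fold higher number from compound 1 to compound 3 (0.29 log units; that floor lies within the scatter), so this limit does not by itself separate compound 3 from compound 1 in this assay. What it adds is that losing the 2-methoxyphenyl group does not always lower the number on this sulfur: the lowering seen with compound 2 did not appear with compound 3.

On these data alone, how far compound 3 lies past the limit remains open. Also open, as far as these compounds go, is whether the chlorine or its place on the phenyl ring matters more, a question that 2-chlorophenyl and 3-methoxyphenyl on the same sulfur would bear on.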